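Predicted Tolerance of a Chloro Analogue Bearing Phenylethenyl Imine

The source may report more compounds than this note shows. Statements on the series, on what has been measured and on what is new or still open speak of the compounds shown alone.

Compound 1, `Oc1ccccc1/C=N/c1sc2c(c1-c1nc3ccccc3s1)CCC2`: 100 ug/mL in an ADME assay on cells (Rhabdomyosarcoma cell, Homo sapiens) for cytotoxicity, read by MTT assay, with a stated time of 72 h; a lower number here means that less compound is tolerated, a higher number that more compound is tolerated
Compound 2, `C(=C/c1ccccc1)\C=N\c1sc2c(c1-c1nc3ccccc3s1)CCC2`: 122 ug/mL in this assay
Compound 3, `Oc1ccccc1/C=N/c1sc2c(c1-c1nc3cc(Cl)ccc3s1)CCC2`: 269 ug/mL in this assay

Compound 3 gives the highest number of the three, with its steps to compound 1 and compound 2 both beyond the scatter. Compound 4, `Clc1ccc2sc(-c3c(/N=C/C=C/c4ccccc4)sc4c3CCC4)nc2c1`, has not yet been measured in this assay. It differs from compound 3 by 2-phenylethenyl in place of 2-hydroxyphenyl on a carbon with a double bond to nitrogen. The same change is seen between compound 1 and compound 2, (2-phenylethenyl in place of 2-hydroxyphenyl on a carbon with a double bond to nitrogen), and there it produced a 1.2-fold higher number from compound 1 to compound 2 (0.09 log units; within the scatter). The cores of the two pairs differ by chloro in place of hydrogen on an aromatic carbon, a change that gave a 2.7-fold higher number from compound 1 to compound 3 (0.43 log units; beyond the scatter).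

For the measured compounds named here, since the change from compound 1 to compound 2 stayed within the scatter, the step of a 1.2-fold higher number from compound 3 to compound 4 (0.08 log units; within the scatter) from compound 3 to compound 4 in this assay is expected to be of similar small size, resting on the single earlier pair. Compound 4 is therefore estimated at 320 ug/mL in this assay, most likely between 160 ug/mL and 640 ug/mL.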

Compound 4, half-maximal cytotoxic concentration: 122 ug/mL
The estimate for compound 4 lay 2.6-fold (0.42 log units) above the measured number, and the stated range ends above it.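

In this assay, 2-phenylethenyl in place of 2-hydroxyphenyl gave a 2.2-fold lower number from compound 3 to compound 4 (0.34 log units; beyond the scatter), so the change did not carry over from the core of compound 1 to the chloro-bearing core of compound 3: the same change on two cores in this assay, a 1.2-fold higher number (0.09 log units; within the scatter) from compound 1 to compound 2 and a 2.2-fold lower number (0.34 log units; beyond the scatter) from compound 3 to compound 4, 2.7-fold (0.43 log units) apart, beyond the scatter of two such steps The chloro change did not carry over either, giving no change at the digits printed from compound 2 to compound 4 (within the scatter) once 2-phenylethenyl was present: the same change on two cores in this assay, a 2.7-fold higher number (0.43 log units; beyond the scatter) from compound 1 to compound 3 and no change at the digits printed (within the scatter) from compound 2 to compound 4, 2.7-fold (0.43 log units) apart, beyond the scatter of two such steps This single set of four compounds shows that, in this series, the step for one change depended on the other place, but it does not show why, and it cannot say whether the same would hold on any further core.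

The compounds shown leave open whether a plain phenyl, which lacks the hydroxyl group and the double bond outside the ring, would behave like 2-hydroxyphenyl or like 2-phenylethenyl on the carbon with a double bond to nitrogen. They also leave open whether fluoro or methoxy in place of chloro would depend on that group in the same way.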